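The compounds below may be only part of what the source reports. "The series", "measured", "known", "first", "only" and "open" are said of these compounds alone.

Measured so far:
Compound 1, `O=C(NC1CCCCC1)NS(=O)(=O)c1ccc(-n2nc(-c3ccccc3)ccc2=O)cc1`: 52.1%
Compound 2, `CCCNC(=O)NS(=O)(=O)c1ccc(-n2nc(-c3ccc(C)cc3)ccc2=O)cc1`: 80.5%
Compound 3, `CCCCNC(=O)NS(=O)(=O)c1ccc(-n2nc(-c3ccc(C)cc3)ccc2=O)cc1`: 86.6%

In a functional assay on the whole organism (blood, strain Wistar albino) for inhibition, with Rattus norvegicus as the target, read by colorimetric assay, with stated times of 15 min and 90 min, at a dose of 20 mg/kg by the oral route (a higher number here means more inhibition at the dose given (going by the name of the read-out), a lower number less inhibition), compound 3 gives the highest of the three numbers. Its nearest neighbour is compound 2, and the step of a number 6.1 percentage points higher from compound 2 to compound 3 (within the scatter) lies within the scatter, so these two cannot be ordered. Compound 1 stands far lower, beyond the scatter, but it differs from compound 3 in more than one place, so its value alone does not say which difference matters.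

Compound 4, `Cc1ccc(-c2ccc(=O)n(-c3ccc(S(=O)(=O)NC(=O)NC4CCCCC4)cc3)n2)cc1`, is not yet measured. It differs from compound 3 only at the urea end: cyclohexyl in place of butyl on an amide-type nitrogen. Within the data shown here, the one measured step that touches this part of the molecule, from compound 2 to compound 3, was a small extension of the chain and stayed within the scatter. Among the measured compounds shown here, compound 1, the only other compound carrying cyclohexyl there, gives 52.1%, yet its second difference leaves this unexplained. The expected step of a number 16.6 percentage points lower from compound 3 to compound 4 (beyond the scatter) in this assay is therefore modestly downward with wide uncertainty. Compound 4 is estimated at 70%, between 50% and 90%.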

Compound 4, a percentage reported as inhibition, in the whole organism at one dose (the size of the read-out at that dose, not a potency): 79.9%
The estimate for compound 4 lay 9.9 percentage points below the measured number, within the range that was stated.
By their numbers in this assay, from the lowest: compound 1; then compounds 4, 2 and 3 (each within the scatter of the next).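

In this assay, the urea end accepts a ring as well as a chain: cyclohexyl in place of butyl gives a number 6.7 percentage points lower from compound 3 to compound 4 (within the scatter) and cyclohexyl in place of propyl gives a number 0.6 percentage points lower from compound 2 to compound 4 (within the scatter) so compounds 2, 3 and 4 cannot be ordered. Cyclohexyl therefore does not by itself bring the low number of compound 1, and the clear gap now sits at the other place, where methyl in place of hydrogen on an aromatic carbon goes with a number 27.8 percentage points higher from compound 1 to compound 4 (beyond the scatter) as the only change here beyond the scatter. Nothing measured here gives a reason for either result.

Still open, from the compounds shown here alone, is how a methoxy group or a chlorine in place of that methyl would read. Also open, going by these compounds, is whether a longer chain such as octyl, or a smaller ring such as cyclopentyl, on the urea nitrogen would stay level with compounds 2, 3 and 4.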